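The source may report more compounds than this note shows. Statements on the series, on what has been measured and on what is new or still open speak of the compounds shown alone.

Of the compounds shown here, three built on two related cores have been tested in a functional assay on PC-3 cells (Homo sapiens) for antiproliferative activity, read by MTT assay, with a stated time of 48 h; on this read-out lower numbers stand for stronger inhibition and higher numbers for weaker inhibition. Compound 1, `Cc1ccc2nc(Nc3nc(Nc4ccc(S(C)(=O)=O)cc4)ncc3F)sc2c1`, reaches only the limit of this assay, giving > 50000 nM. Compound 2, `CS(=O)(=O)c1ccc(Nc2ncc(F)c(Nc3nc4ccc(F)cc4s3)n2)cc1`, likewise ends at a limit in this assay, with > 50000 nM. Compound 3, `COc1ccc2nc(Nc3nc(Nc4ccc(S(N)(=O)=O)cc4)ncc3C)sc2c1`, also stops at a limit in this assay, with > 50000 nM. The change from compound 1 to compound 2, (fluoro in place of methyl on an aromatic carbon), made a step that the two limits leave unreadable from compound 1 to compound 2. The core of compound 3 differs from the core of compound 1, but the difference between the two cores is not broken down here.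

Compound 4, `COc1ccc2nc(Nc3nc(Nc4ccc(S(N)(=O)=O)cc4)ncc3F)sc2c1`, has not yet been measured in this assay. It differs from compound 3 by fluoro in place of methyl on an aromatic carbon. This is the same kind of change as that between compound 1 and compound 2, though the place differs: in compound 1 the methyl sits on an aromatic carbon of a six-membered aromatic ring of carbon only, part of a fused or bridged system of two rings, meta to a fused ring and para to a fused ring, whereas in compound 3 it sits on an aromatic carbon of a six-membered aromatic ring with 2 nitrogen, ortho to a large group, two atoms from the ring nitrogen and para to a large group.

The step from compound 3 to compound 4 is expected to be a step that the limit leaves unreadable from compound 3 to compound 4, an expectation resting on the limit of > 50000 nM in this assay, at which 3 of the 3 values shown sit, and on a step that the two limits leave unreadable from compound 1 to compound 2. Compound 4 is therefore estimated at 60000 nM, expected to lie between 20000 nM and 150000 nM, most probably as a limit once more.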

Compound 4, half-maximal inhibitory concentration: > 50000 nM
Compound 4 gave a limit, no number (the forecaster's own chance of this, stated with the estimate: 85%); the middle value does not contradict the limit.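

Compound 3 and compound 4 both end at a limit in this assay, so no new step can be read between them, and the same holds for every compound shown: the limit of > 50000 nM in this assay, at which 4 of the 4 values shown sit. The compounds shown leave open how large a change fluoro in place of methyl makes on either core, and which structural change, if any, would bring a measurable value in this assay.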